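The compounds below may be only part of what the source reports. "The series", "measured", "known", "first", "only" and "open" are said of these compounds alone.

Compound 3 `C#CCNC1CCc2c(SCCc3cccc(Cl)c3)cccc21` is the weakest of the three measured compounds in an assay on isolated protein for inhibition of Amine oxidase [flavin-containing] B (Homo sapiens) (on this read-out lower numbers stand for stronger inhibition and higher numbers for weaker inhibition), where compound 3 gives 82400 nM. Compound 2 `C#CCNC1CCc2c(SCCc3cccc(Br)c3)cccc21` gives 30500 nM, and compound 1 `C#CCNC1CCc2c(SCc3ccc(Cl)cc3Cl)cccc21` gives 3760 nM. Among the compounds with values here, the step of a 2.7-fold higher number from compound 2 to compound 3 (0.43 log units; beyond the scatter) is the only single change measured here, and it was modest. Compound 4 `C#CCNC1CCc2c(SCCc3cccc(C)c3)cccc21` differs from compound 3 by methyl in place of chloro on an aromatic carbon. Within the data shown here, no measured step swaps a halogen for a methyl, so the expectation rests on the modest size of the one halogen swap seen. The change is therefore expected to bring a 1.2-fold higher number from compound 3 to compound 4 (0.08 log units; within the scatter), with no clear direction beyond the scatter. Compound 4 is expected to give about 100000 nM, within a range from 30000 nM to 300000 nM.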

Compound 4, half-maximal inhibitory concentration: 0.35 nM
For compound 4 the middle estimate is 290000-fold (5.46 log units) above the measured one; the whole stated range lies above it.
By their numbers in this assay, from the lowest: compound 4; then compound 1; then compound 2; then compound 3.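

Replacing a halogen with methyl at this place on the ring gives a 240000-fold lower number from compound 3 to compound 4 (5.37 log units; beyond the scatter) in this assay and also an 87000-fold lower number from compound 2 to compound 4 (4.94 log units; beyond the scatter) there. Within the data shown here, the swap between the two halogens, a 2.7-fold higher number from compound 2 to compound 3 (0.43 log units; beyond the scatter) and no more, gave no hint that this single-atom change could move the number so far. Nothing available here accounts for a step of this size.

On these data alone, whether an ethyl, a methoxy or a trifluoromethyl group at this place would also give so low a number remains open. So does the result with plain hydrogen there.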